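Swapping a Pentyl Chain for Isobutyl on the Amide

The compounds below may be only part of what the source reports. "The series", "measured", "known", "first", "only" and "open" are said of these compounds alone.

For the measured compounds named here, compound 1 `C=CC1=C(C(=O)NCCCCC)C(c2ccc(Cl)c(Cl)c2)OC1` is the one member of this small set with a real number: in a functional assay on SW480 cells (Homo sapiens) for cytotoxicity, read by MTT assay, with a stated time of 24 h (on this read-out lower numbers stand for stronger inhibition and higher numbers for weaker inhibition), compound 1 gives 27500 nM. The other two compounds reach only the limit of the assay. Compound 2 `C=CC1=C(C(=O)O)C(c2ccc(OC)cc2)OC1` gives > 100000 nM, which is a limit and not a number. Compound 3 `C=CC1=C(C(=O)NCc2ccccc2F)C(c2ccc(F)cc2)OC1` gives > 100000 nM, again a limit rather than a number. Going by the values given here, compound 1 therefore stands alone as the only measured value, and the remaining two sit at the limit of > 100000 nM in this assay, at which 2 of the 3 values shown sit.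

Compound 4 `C=CC1=C(C(=O)NCC(C)C)C(c2ccc(Cl)c(Cl)c2)OC1` differs from compound 1 in a single place: isopropyl in place of butyl on a saturated chain carbon bound to an amide-type nitrogen, so that the pentylamino group becomes an isobutylamino group. Among the compounds with values here, no pair of measured compounds shows this change, so its effect is not known from the data. The change is a modest trimming of a saturated chain, and a step of no more than the usual scatter is expected, perhaps leaning slightly towards weaker inhibition. Compound 4 is expected to give about 35000 nM in this assay, with a range from 12000 nM to 100000 nM. The expected step from compound 1 to compound 4 is estimated at a 1.3-fold higher number from compound 1 to compound 4 (0.10 log units; within the scatter), a shift that would remain within the scatter of repeated measurements.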

Compound 4, half-maximal inhibitory concentration: > 100000 nM
Compound 4 was reported as a limit (the forecaster's own chance of this, stated with the estimate: 30%); middle value at least 2.8-fold (0.45 log units) away from the limit.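

In this assay, the chain on the amide nitrogen proves to be a sensitive spot, with a step of an at least 3.6-fold higher number from compound 1 to compound 4 (0.56 log units; beyond the scatter). Isopropyl in place of butyl is the only difference between these two compounds, so this pair isolates a single change in a way that the earlier compounds, which differ from compound 1 in more than one place, could not. The true size of the step remains unknown, and compound 1 is still the only compound here with a real number: the limit of > 100000 nM in this assay, at which 3 of the 4 values shown sit.

On these data alone, whether the loss of activity follows from the shorter chain or from its branching stays open, and a straight butyl chain on the amide nitrogen would help to separate the two. As far as these compounds go, it is equally open whether a longer chain, such as hexyl, would give a lower number than compound 1 or whether the pentyl chain already lies close to the best length for this position.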